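This account rests on a few compounds, and the source may have more. Where it says the series, first, only, none or still open, it means among the compounds named here.

Measured in an ADME assay on S9 fraction from liver (Rattus norvegicus) for metabolic stability, read by LC-MS, using NADPH, with a stated time of 30 min; on this read-out higher numbers stand for a more stable compound and lower numbers for a less stable compound:
- compound 1 `CCCCCCCCc1ccc(OCC(=O)Cn2nnc(-c3cccs3)n2)cc1`: 8%
- compound 2 `CCCCCCCCc1ccc(OCC(=O)Cn2nnc(CCC(=O)O)n2)cc1`: < 5%

For compound 2, < 5% is a limit of the assay and not a number. This is the limit of < 5% in this assay, at which 1 of the 2 values shown sits.

Compound 3 `CCCCCCCCc1ccc(OCC(=O)Cn2nnc(-c3cccc(C(=O)O)c3)n2)cc1` carries 3-carboxyphenyl in place of 2-carboxyethyl on an aromatic carbon, the change being (3-carboxyphenyl in place of 2-carboxyethyl on an aromatic carbon). For the measured compounds named here, the one measured step at this place is a number at least 3 percentage points lower from compound 1 to compound 2 (that floor lies within the scatter). Going by the values given here, with only that step to go on, no change beyond the scatter is expected in this assay. The expected step is a number at least 1 percentage points higher from compound 2 to compound 3 (that floor lies within the scatter). For compound 3 the estimate is 6%, with an expected range from 3% to 14%.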

Compound 3, percent of the compound remaining: < 5%
Compound 3 gave a limit, no number; the forecaster's own chance of this, stated with the estimate: 45%; middle value at least 1 percentage points from the limit.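

In this assay compound 3 gives < 5%, a limit of the assay and not a number. The change from thiophen-2-yl to 3-carboxyphenyl on this aromatic carbon is a number at least 3 percentage points lower from compound 1 to compound 3 (that floor lies within the scatter), so carrying the carboxylic acid on a six-membered aromatic ring rather than on the 2-carboxyethyl chain did not lift the value off the limit. The step between the two acid-bearing compounds cannot be read: the limit of < 5% in this assay, at which 2 of the 3 values shown sit.

Going by these compounds, whether an amine or a longer alkyl chain on this carbon would leave more compound remaining stays open.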